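The source may report more compounds than this note shows. Statements on the series, on what has been measured and on what is new or still open speak of the compounds shown alone.

Two measured compounds frame this step. Compound 1 `COc1ccc(-c2cc(/C=C/C(=O)c3ccc(N)cc3)[nH]n2)cc1` gives 3420 nM in a functional assay on KM12 cells (Homo sapiens) for inhibition, read by sulforhodamine B assay, with a stated time of 48 h; a lower number here means a stronger inhibitor of growth, a higher number a weaker inhibitor of growth. Compound 2 `COc1cc(-c2cc(/C=C/C(=O)c3ccc(N)cc3)[nH]n2)cc(OC)c1OC` gives 2880 nM in this assay, the lower of the two numbers, though the gap to compound 1 lies within the scatter, so the two stand as equals.

Compound 3 `COc1ccc(-c2cc(/C=C/C(=O)c3ccc(N)cc3)[nH]n2)cc1OC` differs from compound 2 in one place: hydrogen in place of methoxy on an aromatic carbon. With compound 1 at one methoxy and compound 2 at three sitting level, a change to two gives no ground for a move in either direction. The step from compound 2 to compound 3 is expected to be a 1.1-fold higher number from compound 2 to compound 3 (0.03 log units; within the scatter), none beyond the scatter. For compound 3 the estimated value in this assay is 3100 nM, with a range from 1500 nM to 6500 nM.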

Compound 3, concentration for total growth inhibition: 3350 nM
Estimate against measurement, compound 3: 1.1-fold (0.03 log units) below; low and high end bracket the measured number.
By their numbers in this assay, from the lowest: compounds 2, 3 and 1 (each within the scatter of the next).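

In this assay, among the compounds shown here, the single changes can now be read directly: hydrogen in place of methoxy on an aromatic carbon gives a 1.2-fold higher number from compound 2 to compound 3 (0.07 log units; within the scatter), and methoxy in place of hydrogen on an aromatic carbon gives a 1.0-fold lower number from compound 1 to compound 3 (0.01 log units; within the scatter). Both steps stay within the scatter, so for these three compounds neither change separates its pair, and the methoxy group and hydrogen stand level at each of the two carbons. Nothing available gives a reason for this level reading.

The compounds shown leave open whether a different group on these carbons, such as a hydroxyl, a fluorine or a dimethylamino group, would shift the number beyond the scatter. They also leave open what an acetamide in place of the amine on the other aromatic ring would do.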